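From 3-methylphenyl to 4-phenylphenyl on a shared core

The source may hold more compounds than are shown below. What is called first, only, known or untested is meant among the compounds shown, and "the series" means these compounds.

In a functional assay on HepG2 cells (Homo sapiens) for inhibition, read by MTT assay, with a stated time of 72 h (a lower number here means a stronger inhibitor, a higher number a weaker inhibitor), compound 1 (`O=C1/C(=C\c2ccccc2)c2c(ncn2COCc2ccccc2)CCN1Cc1ccccc1`) gives 13900 nM, compound 2 (`O=C1/C(=C\c2ccccc2)c2c(ncn2COCc2ccccc2)CCN1Cc1ccc(F)cc1`) gives 39400 nM and compound 3 (`Cc1cccc(CN2CCc3ncn(COCc4ccccc4)c3/C(=C/c3ccccc3)C2=O)c1`) gives 34300 nM. Compound 3 therefore shares the high end of these numbers, with a 1.1-fold lower number from compound 2 to compound 3 (0.06 log units; within the scatter). Compound 4 (`O=C1/C(=C\c2ccccc2)c2c(ncn2COCc2ccccc2)CCN1Cc1ccc(-c2ccccc2)cc1`) has 4-phenylphenyl in place of 3-methylphenyl on a saturated chain carbon bound to an amide-type nitrogen in a ring. The nearest evidence is modest: a 2.8-fold higher number from compound 1 to compound 2 (0.45 log units; beyond the scatter), and a 2.5-fold higher number from compound 1 to compound 3 (0.39 log units; beyond the scatter). Neither step adds a second aromatic ring, so the precedent is indirect, and no step beyond the scatter is expected. The expected change is a 1.2-fold higher number from compound 3 to compound 4 (0.07 log units; within the scatter). Compound 4 is estimated at 40000 nM, with an expected range from 15000 nM to 100000 nM.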

Compound 4, half-maximal inhibitory concentration: 72500 nM
Estimate against measurement, compound 4: 1.8-fold (0.26 log units) below; measured number inside the range.
By their numbers in this assay, from the lowest: compound 1; then compounds 3, 2 and 4 (each within the scatter of the next, the first and the last beyond it).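

At the saturated chain carbon bound to an amide-type nitrogen in a ring, this assay now shows what a second aromatic ring does: there is a 2.1-fold higher number from compound 3 to compound 4 (0.33 log units; beyond the scatter) and a 5.2-fold higher number from compound 1 to compound 4 (0.72 log units; beyond the scatter) while phenyl in place of fluoro gives a 1.8-fold higher number from compound 2 to compound 4 (0.26 log units; within the scatter) and stays within the scatter. All three groups added to the aromatic ring of compound 1 leave a higher number than compound 1 gives, and none of the compounds shown goes against this. As far as these compounds go, whether an amine or a carboxylic acid on that ring would do the same remains open. So does whether any group there could bring the number below that of compound 1. No measurement shown here bears on what lies behind these rises.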